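This account rests on a few compounds, and the source may have more. Where it says the series, first, only, none or still open, it means among the compounds named here.

Compound 1 `CS(=O)(=O)Nc1ccc2c(c1)S(=O)(=O)C=C(c1c(O)c3cc(F)ccc3n(Cc3ccc(F)cc3)c1=O)N2` is the reference point of this series. In an ADME assay on 2209-23 cells (Homo sapiens) for cytotoxicity, read by WST assay (a lower number here means that less compound is tolerated, a higher number that more compound is tolerated), compound 1 reaches only a limit of the assay, > 50000 nM. Compound 2 `CN(c1ccc2c(c1)S(=O)(=O)C=C(c1c(O)c3cc(F)ccc3n(Cc3ccc(F)cc3)c1=O)N2)S(C)(=O)=O` carries a methyl in place of hydrogen on the sulfonamide nitrogen. In this assay compound 2 likewise stops at a limit, > 50000 nM. The step that the two limits leave unreadable from compound 1 to compound 2 therefore cannot be sized, as both values stand at the limit of > 50000 nM in this assay, at which 2 of the 2 values shown sit. Compound 3 `CS(=O)(=O)Nc1ccc2c(c1)S(=O)(=O)C=C(c1c(O)c3ccccc3n(Cc3ccc(F)cc3)c1=O)N2` differs from compound 1 by hydrogen in place of fluoro on an aromatic carbon. Going by the values given here, no measured step bears directly on this change, and the only recorded step is unreadable, so no direction beyond the scatter can be expected in this assay. With both measured compounds at the limit, compound 3 is expected to remain there as well, with an expected step of a number no higher from compound 1 to compound 3 (the limit leaves the size open). Compound 3 is estimated at 50000 nM, between 25000 nM and 100000 nM, most likely reported again only as a limit.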

Compound 3, half-maximal cytotoxic concentration: > 50000 nM
Compound 3 gave a limit, no number; the forecaster's own chance of this, stated with the estimate: 90%; the middle value sits exactly at the limit.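

No step can be read from compound 1 to compound 3 in this assay as both compounds stand at a limit of the assay: (the limit of > 50000 nM in this assay, at which 3 of the 3 values shown sit). The compounds shown leave open whether hydrogen in place of fluoro, or methyl in place of hydrogen on the sulfonamide nitrogen, changes the tolerated concentration at all.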